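From Trifluoromethyl to Methoxy: Expecting a Gain

The source may report more compounds than this note shows. Statements on the series, on what has been measured and on what is new or still open speak of the compounds shown alone.

Compound 1 `COc1ccc(N/C=C\C(=O)c2cn(-c3ccccc3)nc2-c2ccc(F)cc2)cc1`: 2500 nM
Compound 2 `O=C(/C=C\Nc1ccc(F)cc1)c1cn(-c2ccccc2)nc1-c1ccc(Cl)cc1`: 17900 nM
Compound 3 `O=C(/C=C\Nc1ccc(C(F)(F)F)cc1)c1cn(-c2ccccc2)nc1-c1ccc(Cl)cc1`: > 50000 nM

These three compounds were tested in a functional assay on U-87MG ATCC cells (Homo sapiens) for antiproliferative activity, read by MTT assay, with a stated time of 48 h; on this read-out higher numbers stand for weaker inhibition and lower numbers for stronger inhibition. Compound 1 gives 2500 nM, and compound 2 gives 17900 nM. For compound 3 the reported value is only a limit of the assay, > 50000 nM, so compound 3 stands at the limit of > 50000 nM in this assay, at which 1 of the 3 values shown sits. The step of an at least 2.7-fold higher number from compound 2 to compound 3 (0.44 log units; beyond the scatter) shows that bringing in trifluoromethyl cost potency.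

Compound 4 `COc1ccc(N/C=C\C(=O)c2cn(-c3ccccc3)nc2-c2ccc(Cl)cc2)cc1` reverses part of that loss: methoxy in place of trifluoromethyl on an aromatic carbon. For the measured compounds named here, the methoxy that enters here is the one carried by compound 1, which gives 2500 nM, so the substitution is expected to be favourable. Since compound 3 sits at a limit, the expected step of an at least 12-fold lower number from compound 3 to compound 4 (1.09 log units; beyond the scatter) can only be read as a move downward from that limit. Compound 4 is therefore estimated at 4000 nM, within a range from 1500 nM to 15000 nM.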

Compound 4, half-maximal inhibitory concentration: 6890 nM
Compound 4: the middle estimate sits 1.7-fold (0.24 log units) below what was measured; measured number inside the range.
By their numbers in this assay, from the lowest: compound 1; then compound 4; then compound 2. At a limit, above all of these: compound 3.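

In this assay, with the chlorophenyl side of the molecule unchanged, methoxy gives lower numbers than either other group shown at this position, fluoro and trifluoromethyl: a 2.6-fold lower number from compound 2 to compound 4 (0.41 log units; beyond the scatter), and an at least 7.2-fold lower number from compound 3 to compound 4 (0.86 log units; beyond the scatter). Compound 3 is only a limit of the assay, so the second of these steps gives a minimum size rather than an exact one: the limit of > 50000 nM in this assay, at which 1 of the 4 values shown sits. With methoxy kept in place, a change elsewhere in the molecule also shifts the result, as chloro in place of fluoro gives a 2.8-fold higher number from compound 1 to compound 4 (0.44 log units; beyond the scatter).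

The compounds shown do not tell why methoxy does better than fluoro or trifluoromethyl. From the compounds shown here alone, it also remains open whether an amine, a hydroxyl group or a longer chain such as ethoxy at this position would give a lower number still, and whether chloro in place of fluoro would have the same effect alongside these groups.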